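A few compounds are considered here, and "the series" means these few. Any claim that something is new, unique, unknown or untested is made for them only; others in the source may bear on it.

Compound 1 `Cc1ccc(CNc2nc(-c3ccccc3C(F)(F)F)nc3ccccc23)s1` gives 5100 nM in an assay on a protein complex for inhibition of ubiquitin carboxyl-terminal hydrolase 1/WD repeat-containing protein 48 (Homo sapiens), read by fluorescence; on this read-out lower numbers stand for stronger inhibition and higher numbers for weaker inhibition. For the measured compounds named here, compound 2 `N#Cc1ccc(CNc2nc(-c3ccccc3C(F)(F)F)nc3ccccc23)cc1` gives 5700 nM in this assay, the higher of the two numbers, although the only step recorded, a 1.1-fold higher number from compound 1 to compound 2 (0.05 log units; within the scatter), stays within the scatter. Compound 3 `FC(F)(F)c1ccccc1-c1nc(NCc2ccc(C3CCCCC3)cc2)c2ccccc2n1` differs from compound 2 by cyclohexyl in place of cyano on an aromatic carbon. Going by the values given here, no measured step concerns a cyclohexyl group, and the one step available, a 1.1-fold higher number from compound 1 to compound 2 (0.05 log units; within the scatter), shows that exchanging the group at this position changed little in this assay. The expected step is therefore a 1.1-fold lower number from compound 2 to compound 3 (0.06 log units; within the scatter), nothing beyond the scatter. Compound 3 is estimated at 5000 nM, within a range of 1500 nM to 16000 nM.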

Compound 3, half-maximal inhibitory concentration: 9800 nM
The estimate for compound 3 lay 2.0-fold (0.29 log units) below the measured number, within the range that was stated.
By their numbers in this assay, from the lowest: compounds 1, 2 and 3 (each within the scatter of the next).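

Cyclohexyl in place of cyano on an aromatic carbon, para to a large group, gives a 1.7-fold higher number from compound 2 to compound 3 (0.24 log units; within the scatter) in this assay. The earlier step exchanged the whole aromatic group on the chain carbon; this one shows that a much larger, non-aromatic carbon ring without a hydrogen-bond acceptor, replacing cyano on the same ring, still leaves compound 3 within the scatter of compound 2. No supporting data bear on this result.

On these data alone, whether an amine or a carboxylic acid on this aromatic carbon would stay within the scatter remains open. So does whether any group here can give a step beyond it.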